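A few compounds are considered here, and "the series" means these few. Any claim that something is new, unique, unknown or untested is made for them only; others in the source may bear on it.

In a functional assay on RS4-11 cells (Homo sapiens) for inhibition, read by CCK-8 assay, with a stated time of 72 h (on this read-out higher numbers stand for weaker inhibition and lower numbers for stronger inhibition), compound 3 (`CC1(C)CCC(CN2CCN(c3ccc(C(=O)NS(=O)(=O)c4ccc(OCC5CCSCC5)c([N+](=O)[O-])c4)c(Oc4cnc5[nH]ccc5c4)c3)CC2)=C(c2ccc(C(F)(F)F)cc2)C1`) gives 15 nM, the highest number of the three, while compound 1 (`CC1(C)CCC(CN2CCN(c3ccc(C(=O)NS(=O)(=O)c4ccc(NCC5CCOCC5)c([N+](=O)[O-])c4)c(Oc4cnc5[nH]ccc5c4)c3)CC2)=C(c2ccc(C(F)(F)F)cc2)C1`) gives 6.2 nM and compound 2 (`CN(C)CCCNc1ccc(S(=O)(=O)NC(=O)c2ccc(N3CCN(CC4=C(c5ccc(C(F)(F)F)cc5)CC(C)(C)CC4)CC3)cc2Oc2cnc3[nH]ccc3c2)cc1[N+](=O)[O-]`) gives 3.9 nM. Compound 4 (`CN1CCC(COc2ccc(S(=O)(=O)NC(=O)c3ccc(N4CCN(CC5=C(c6ccc(C(F)(F)F)cc6)CC(C)(C)CC5)CC4)cc3Oc3cnc4[nH]ccc4c3)cc2[N+](=O)[O-])C1`) differs from compound 3 as follows: 1-methylpyrrolidin-3-yl in place of thian-4-yl on a saturated chain carbon bound to an oxygen on an aromatic ring. In other words, (thian-4-yl)methyl becomes (1-methylpyrrolidin-3-yl)methyl. Among the measured compounds shown here, no measured step makes this exact swap. The closest evidence is a 3.8-fold higher number from compound 2 to compound 3 (0.59 log units; beyond the scatter) and a 2.4-fold higher number from compound 1 to compound 3 (0.38 log units; beyond the scatter), and both of these also exchange the nitrogen on the aromatic ring for an oxygen. The step of a 1.6-fold lower number from compound 1 to compound 2 (0.20 log units; within the scatter) shows that the 2-(dimethylamino)ethyl chain and oxan-4-yl do not separate. A modest step is therefore expected, a 2.1-fold lower number from compound 3 to compound 4 (0.33 log units; beyond the scatter). The estimated value for compound 4 is 7 nM, within an expected range from 2.5 nM to 20 nM.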

Compound 4, half-maximal inhibitory concentration: 10 nM
Compound 4: the middle estimate sits 1.4-fold (0.15 log units) below what was measured; the range from low to high includes it.
By their numbers in this assay, from the lowest: compounds 2, 1, 4 and 3 (each within the scatter of the next, the first and the last beyond it).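

On a saturated chain carbon bound to an oxygen on an aromatic ring, 1-methylpyrrolidin-3-yl and thian-4-yl do not separate in this assay (a 1.5-fold lower number from compound 3 to compound 4 (0.18 log units; within the scatter)). (1-Methylpyrrolidin-3-yl)methoxy also does not separate from ((oxan-4-yl)methyl)amino (a 1.6-fold higher number from compound 1 to compound 4 (0.21 log units; within the scatter)), but it does separate from (3-(dimethylamino)propyl)amino (a 2.6-fold higher number from compound 2 to compound 4 (0.41 log units; beyond the scatter)). Nothing measured here accounts for these steps. The compounds shown leave open how a carboxylic acid or a morpholine on that same chain carbon would read, and whether a longer chain before the 1-methylpyrrolidin-3-yl ring would shift the number.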